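A few compounds are considered here, and "the series" means these few. Any claim that something is new, unique, unknown or untested is made for them only; others in the source may bear on it.

Of the compounds shown here, two have been measured in a functional assay on MCF7 cells (Homo sapiens) for cytotoxicity, read by sulforhodamine B assay, with a stated time of 3 days; on this read-out higher numbers stand for weaker inhibition and lower numbers for stronger inhibition. Compound 1 `Cc1cn(C2CN(S(=O)(=O)c3ccccc3[N+](=O)[O-])c3ccccc3CO2)c(=O)[nH]c1=O` gives 45200 nM, while compound 2 `O=[N+]([O-])c1ccccc1S(=O)(=O)N1CC(n2cnc3c(I)nc(Cl)nc32)OCc2ccccc21` gives 610 nM. For the measured compounds named here, the one measured step, a 74-fold lower number from compound 1 to compound 2 (1.87 log units; beyond the scatter), is large, and on these two numbers compound 2 stands lowest, with compound 1 the only neighbour and far above it.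

Compound 3 `O=[N+]([O-])c1ccccc1S(=O)(=O)N1CC(n2cnc3nc(Cl)nc(Cl)c32)OCc2ccccc21` keeps the core of compound 2 and changes only the group on the saturated ring carbon: a group of 11 heavy atoms (5 carbon, 4 nitrogen, 2 chlorine; one five-membered aromatic ring with 2 hetero atoms, one six-membered aromatic ring with 2 hetero atoms) in place of a group of 11 heavy atoms (5 carbon, 4 nitrogen, 1 chlorine, 1 iodine; one five-membered aromatic ring with 2 hetero atoms, one six-membered aromatic ring with 2 hetero atoms), on a saturated ring carbon. The leaving group and the entering group have the same ring count and the same number of hydrogen-bond acceptors, the difference being one chlorine in place of the iodine.

Going by the values given here, no measured step mirrors this change. The step from compound 1 to compound 2 replaced a different kind of group altogether, so it says little about swapping one halogen for another on an otherwise unchanged group. Because compound 2 already gives 610 nM with the closely related group, compound 3 is expected to stay near it, with a step of a 1.3-fold higher number from compound 2 to compound 3 (0.12 log units; within the scatter) that is expected to lie within the scatter. Compound 3 is therefore estimated at 800 nM, in the range 250 nM to 2500 nM.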

Compound 3, half-maximal inhibitory concentration: 990 nM
Estimate against measurement, compound 3: 1.2-fold (0.09 log units) below; low and high end bracket the measured number.
By their numbers in this assay, from the lowest: compounds 2 and 3 (each within the scatter of the next); then compound 1.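

In this assay, the exchange of the iodine for a second chlorine on the group at this saturated ring carbon is a 1.6-fold higher number from compound 2 to compound 3 (0.21 log units; within the scatter), so the two halogens cannot be told apart on this pair. The step of a 46-fold lower number from compound 1 to compound 3 (1.66 log units; beyond the scatter) is large, like the one seen earlier with the iodine-bearing group, so the large difference from compound 1 does not depend on iodine and appears with either of the two halogen-bearing groups shown. Nothing available here bears on the reason for either result.

As far as these compounds go, it remains open whether an amine or a methoxy group in place of a halogen would keep the number close to those of compound 2 and compound 3, and thus whether any halogen is needed for the large step from compound 1. It is also open whether this holds once the nitro group on the shared core is replaced, for example by a carboxylic acid, since all the compounds shown carry the nitro group.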